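The source may hold more compounds than are shown below. What is called first, only, known or untested is meant among the compounds shown, and "the series" means these compounds.

Compound 1, with the structure `N#Cc1cncc(N2CC[C@H]3CN[C@H]3C2)c1`, and compound 3, with the structure `N#Cc1cncc(N2C[C@@H]3CCNC[C@@H]32)c1`, are built from the same atoms joined in different ways; the difference between the two cores is not broken down here. Both carry a nitrile on a six-membered aromatic ring that contains one nitrogen. In a functional assay on HEK293 cells for agonist activity at Neuronal acetylcholine receptor; alpha4/beta2 (Homo sapiens), read by FLIPR (a higher number here means that more compound is needed for the effect, a lower number that less compound is needed), compound 1 gives 1900 nM, and compound 3 gives 2190 nM; the two numbers lie within the scatter of each other.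

Compound 2, with the structure `N#Cc1cc(N2CC[C@H]3CN[C@H]3C2)cnc1Br`, differs from compound 1 by one change: bromo in place of hydrogen on an aromatic carbon. In this assay compound 2 gives 6.1 nM, which amounts to a 310-fold lower number from compound 1 to compound 2 (2.49 log units; beyond the scatter).

Compound 4, with the structure `N#Cc1cc(N2C[C@@H]3CCNC[C@@H]32)cnc1Br`, has not yet been measured. Within the data shown here, it differs from compound 3 by bromo in place of hydrogen on an aromatic carbon, which is the same change, at a place described in the same words, as the one that turns compound 1 into compound 2. The expectation therefore rests on one measured pair only. Because compound 3 sits at 2190 nM and the earlier step was a 310-fold lower number from compound 1 to compound 2 (2.49 log units; beyond the scatter), the estimated step is a 270-fold lower number from compound 3 to compound 4 (2.44 log units; beyond the scatter). Compound 4 is thus expected to give about 8 nM in this assay, with an estimated range from 2.5 nM to 30 nM.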

Compound 4, half-maximal effective concentration: 109 nM
Compound 4: the middle estimate sits 14-fold (1.13 log units) below what was measured, outside the stated range (above it).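

In this assay, bromo in place of hydrogen on an aromatic carbon, next to the ring nitrogen and ortho to the nitrile, again lowers the number, with a 20-fold lower number from compound 3 to compound 4 (1.30 log units; beyond the scatter), so on both cores shown the change goes the same way and the step is large. The direction carried over from one core to the other, but the size did not, and a step measured on one core would have been a poor guide to the exact size on the other: the same change on two cores in this assay, a 310-fold lower number (2.49 log units; beyond the scatter) from compound 1 to compound 2 and a 20-fold lower number (1.30 log units; beyond the scatter) from compound 3 to compound 4, 16-fold (1.19 log units) apart, beyond the scatter of two such steps. Among these compounds, these two pairs show that the core has a say in how much this change matters, but they do not show why the two steps differ, and with only two cores they cannot tell how large the step would be on a third core or whether its direction would hold there.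

The compounds shown leave open whether chlorine, a methyl group or an amine at this same place would also lower the number on both cores, and whether the two cores would again differ in the size of the step. They also leave open whether bromo would still give a large step if the nitrile were exchanged for an amide or a carboxylic acid.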